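This account rests on a few compounds, and the source may have more. Where it says the series, first, only, none or still open, it means among the compounds named here.

Measured in a functional assay on EBC-1 cells (Homo sapiens) for antiproliferative activity, read by sulforhodamine B assay, with a stated time of 72 h; a lower number here means a stronger inhibitor, a higher number a weaker inhibitor:
- compound 1 `Cn1cc(-c2ccc(=O)n(CCOc3ccnc4cc(OCCCCC(=O)NO)ccc34)n2)cn1`: 370 nM
- compound 2 `Cn1cc(-c2ccc(=O)n(CCOc3ccnc4cc(OCCCCCC(=O)NO)ccc34)n2)cn1`: 460 nM
- compound 3 `Cn1cc(-c2ccc(=O)n(CCOc3ccnc4cc(OCCCCCS)ccc34)n2)cn1`: 640 nM

Compound 3 cannot be separated from the other two on these numbers. The step of a 1.4-fold higher number from compound 2 to compound 3 (0.14 log units; within the scatter) and the step of a 1.7-fold higher number from compound 1 to compound 3 (0.24 log units; within the scatter) both lie within the scatter of repeated measurements.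

Compound 4 `CNC(=O)CCCCCOc1ccc2c(OCCn3nc(-c4cnn(C)c4)ccc3=O)ccnc2c1` has not yet been measured. It carries methylcarbamoyl in place of sulfanyl on a saturated chain carbon, five bonds along the chain from an oxygen on an aromatic ring.

Going by the values given here, the closest precedent is the swap of hydroxycarbamoyl for sulfanyl at that same place, a 1.4-fold higher number from compound 2 to compound 3 (0.14 log units; within the scatter). Lengthening the chain, a 1.2-fold higher number from compound 1 to compound 2 (0.09 log units; within the scatter), also changed little. Among the compounds with values here, no measured compound carries methylcarbamoyl, so the range must stay wide. Even so, with every end group so far within the scatter, no step beyond the scatter is expected in this assay.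

The expected change is a 1.1-fold lower number from compound 3 to compound 4 (0.03 log units; within the scatter). For compound 4, the estimated value is 600 nM, with an expected range of 220 nM to 1700 nM.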

Compound 4, half-maximal inhibitory concentration: 79 nM
Estimate against measurement, compound 4: 7.6-fold (0.88 log units) above; measured number outside the range, below it.
By their numbers in this assay, from the lowest: compound 4; then compounds 1, 2 and 3 (each within the scatter of the next).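

In this assay, the group at the end of this chain can matter after all: the earlier swaps stayed within the scatter, whereas methylcarbamoyl in place of sulfanyl gives an 8.1-fold lower number from compound 3 to compound 4 (0.91 log units; beyond the scatter) on the same chain position. Methyl in place of hydroxy on the amide-type nitrogen gives a 5.8-fold lower number from compound 2 to compound 4 (0.77 log units; beyond the scatter) and the comparison with the shorter hydroxycarbamoyl chain gives a 4.7-fold lower number from compound 1 to compound 4 (0.67 log units; beyond the scatter) in this set, so a hydroxycarbamoyl end is not required for a low number here. Nothing shown explains this gain.

The compounds shown do not tell whether the gain depends on the methyl or on the amide alone, which a plain carboxamide or a carboxylic acid at this chain end would test. They also leave open how a shorter or longer chain would behave with methylcarbamoyl at its end.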